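A few compounds are considered here, and "the series" means these few. Any claim that something is new, unique, unknown or untested is made for them only; others in the source may bear on it.

Compounds measured so far, all in an assay on HEK293 cells for positive allosteric modulation of metabotropic glutamate receptor 5 (Homo sapiens), read by FLIPR, with a stated time of 1 h; a higher number here means that more compound is needed for the effect, a lower number that less compound is needed:

Compound 1, `CN1CCc2nc(C#Cc3ccccc3)sc2C1`: 34 nM
Compound 2, `CC(C)CN1CCc2nc(C#Cc3ccccc3)sc2C1`: the value here is a limit of this assay, > 10000 nM
Compound 3, `CC1CC(C(=O)N2CCc3nc(C#Cc4ccccc4)sc3C2)C1`: 81 nM

Among the two numbers that are not limits, compound 3 gives the higher one, the step being a 2.4-fold higher number from compound 1 to compound 3 (0.38 log units; beyond the scatter). Compound 2 sits at the assay limit (the limit of > 10000 nM in this assay, at which 1 of the 3 values shown sits), so the step of an at least 120-fold lower number from compound 2 to compound 3 (2.09 log units; beyond the scatter) can only be stated as a minimum, as can an at least 290-fold higher number from compound 1 to compound 2 (2.46 log units; beyond the scatter).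

Compound 4, `CC1CCCC(C(=O)N2CCc3nc(C#Cc4ccccc4)sc3C2)C1`, has not been measured. It differs from compound 3 in one place: 3-methylcyclohexyl in place of 3-methylcyclobutyl on a carbonyl carbon. The measured steps that touch the carbonyl-bearing nitrogen, a 2.4-fold higher number from compound 1 to compound 3 (0.38 log units; beyond the scatter) and an at least 120-fold lower number from compound 2 to compound 3 (2.09 log units; beyond the scatter), replace a methyl or an isobutyl with the whole acyl group; none of them alters only the ring on the carbonyl carbon, so they give no direct guide to this change. A step of modest size at most, in either direction, is therefore expected in this assay, with the change most likely lying within the scatter. The estimated step is a 1.2-fold lower number from compound 3 to compound 4 (0.06 log units; within the scatter). Compound 4 is expected to give about 70 nM, within a range from 20 nM to 300 nM.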

Compound 4, half-maximal effective concentration: 100 nM
Compound 4: middle estimate off by 1.4-fold (0.15 log units), on the low side; measured number inside the range.
By their numbers in this assay, from the lowest: compound 1; then compounds 3 and 4 (each within the scatter of the next). At a limit, above all of these: compound 2.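

In this assay the step is a 1.2-fold higher number from compound 3 to compound 4 (0.09 log units; within the scatter), so the two numbers cannot be told apart. The earlier steps shown here swapped the whole group on the ring nitrogen, whereas this one alters only the ring on the carbonyl carbon, and it shows that 3-methylcyclohexyl can stand in place of 3-methylcyclobutyl at this position with no step beyond the scatter. The data shown offer no cause for this result.

As far as these compounds go, whether the position also accepts a carbonyl substituent carrying an amine or a carboxylic acid, or an open longer chain, remains open. Both rings shown carry a methyl, so what happens when that methyl is removed or replaced by an ethyl also remains open.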